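The source may report more compounds than this note shows. Statements on the series, on what has been measured and on what is new or still open speak of the compounds shown alone.

Measured in a functional assay on HT-29 cells (Homo sapiens) for inhibition, read by sulforhodamine B assay, with a stated time of 48 h; a lower number here means that less compound is tolerated, a higher number that more compound is tolerated:
- Compound 1 `COc1cc(-c2nn(-c3cccc(NC(=O)Nc4cc(C(F)(F)F)cc(C(F)(F)F)c4)c3)cc2-c2ccncc2)ccc1Cl`: 3710 nM
- Compound 2 `COc1cc(-c2nn(-c3cccc(NC(=O)c4cccc(C(F)(F)F)c4)c3)cc2-c2ccncc2)ccc1Cl`: > 50000 nM (a limit)
- Compound 3 `O=C(Nc1cccc(-n2cc(-c3ccncc3)c(-c3ccc(Cl)c(O)c3)n2)c1)Nc1ccc(Cl)c(Cl)c1`: > 32500 nM (a limit)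

Compound 1 is the only one of the three with an actual number, as the other two values are limits. Compound 4 `COc1cc(-c2nn(-c3cccc(NC(=O)Nc4cccc(C(F)(F)F)c4)c3)cc2-c2ccncc2)ccc1Cl` has not yet been measured. It differs from compound 1 by hydrogen in place of trifluoromethyl on an aromatic carbon, with hydrogen in place of trifluoromethyl on an aromatic carbon. Among the measured compounds shown here, no measured pair isolates this change, so the expectation is tentative. Like compound 4, compound 2 keeps a lone trifluoromethyl and shows only a limit, > 50000 nM. A moderate upward step in this assay, beyond the scatter, is therefore expected, and the estimate is a 3.2-fold higher number from compound 1 to compound 4 (0.51 log units; beyond the scatter). For compound 4 the estimated value is 12000 nM, with an expected range of 3500 nM to 45000 nM.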

Compound 4, concentration lethal to 50% of the cells: 4670 nM
Estimate against measurement, compound 4: 2.6-fold (0.41 log units) above; the measured number falls inside the stated range.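

In this assay, the position on the aromatic ring tolerates the loss of one trifluoromethyl: hydrogen in its place gives a 1.3-fold higher number from compound 1 to compound 4 (0.10 log units; within the scatter). The change on the carbonyl carbon, (3-(trifluoromethyl)phenyl)amino in place of 3-(trifluoromethyl)phenyl, weighs far more, with an at least 10-fold lower number from compound 2 to compound 4 (1.02 log units; beyond the scatter). The value of compound 2 in that step is a limit, not a number: the limit of > 50000 nM in this assay, at which 1 of the 4 values shown sits.

The compounds shown leave open whether losing the remaining trifluoromethyl would also leave the number within the scatter. They also leave open how an amine or a carboxylic acid would fare on that aromatic carbon.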